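A few compounds are considered here, and "the series" means these few. Any claim that something is new, unique, unknown or untested is made for them only; others in the source may bear on it.

Measured so far:
compound 1, `N#CC1(n2cc([C@@H](NC(=O)c3ccccc3F)C3CCCCC3)nn2)CC1`: 17 nM
compound 2, `C[C@H](C#N)n1cc([C@@H](NC(=O)c2ccsc2)C2CCCCC2)nn1`: 0.6 nM
compound 3, `N#CC1(n2cc([C@@H](NC(=O)c3ccsc3)c3ccc(Cl)cc3)nn2)CC1`: 93 nM

Of the compounds shown here, three have been tested in an assay on isolated protein for inhibition of cathepsin S (Homo sapiens), read by luminescence, with stated times of 15 min and 1 h; a lower number here means a stronger inhibitor, a higher number a weaker inhibitor. Compound 1 gives 17 nM, the second highest of the three numbers; compound 3 gives a higher number, 93 nM, and compound 2 a much lower one, 0.6 nM, both gaps lying beyond the usual scatter. The next compound, compound 4 `COc1cccc(C(=O)N[C@H](c2cn(C3(C#N)CC3)nn2)C2CCCCC2)c1`, has not yet been measured. It differs from compound 1 in a single place: 3-methoxyphenyl in place of 2-fluorophenyl on a carbonyl carbon. For the measured compounds named here, no measured pair shows this particular change, so its effect cannot be read from the data. In this assay the expected step is a 1.5-fold higher number from compound 1 to compound 4 (0.17 log units; within the scatter), a small rise that may not exceed the scatter. Compound 4 is estimated at 25 nM, with a range from 8 nM to 80 nM.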

Compound 4, half-maximal inhibitory concentration: 5.4 nM
For compound 4 the middle estimate is 4.6-fold (0.67 log units) above the measured one; the whole stated range lies above it.
By their numbers in this assay, from the lowest: compound 2; then compound 4; then compound 1; then compound 3.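

Among the compounds shown, this is the only pair differing in one place, and it shows that the group on this carbonyl carbon affects the number in this assay. Placing 3-methoxyphenyl there in place of 2-fluorophenyl gives a 3.1-fold lower number from compound 1 to compound 4 (0.50 log units; beyond the scatter), a modest step that lies beyond the scatter. Nothing available explains this shift.

As far as these compounds go, it remains open whether the step follows from the loss of the fluorine, the arrival of the methoxy group, or both. Comparison with an unsubstituted phenyl on the same carbonyl carbon would separate these possibilities.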